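Chloro for hydrogen on the shared core: compound 2 to compound 4

This account rests on a few compounds, and the source may have more. Where it says the series, first, only, none or still open, it means among the compounds named here.

Of the compounds shown here, three have been measured in a functional assay on K562 cells (Homo sapiens) for cytotoxicity, read by sulforhodamine B assay, with a stated time of 48 h; on this read-out higher numbers stand for weaker inhibition of growth and lower numbers for stronger inhibition of growth. Compound 1 `ClCc1ccc(Cn2cnc3c(Cl)ncnc32)cc1` gives 2910 nM in this assay. Compound 2 `ClCc1ccccc1Cn1cnc2ncnc(Cl)c21` gives 2230 nM in this assay. Compound 3 `ClCc1cccc(Cn2cnc3nc(Cl)nc(Cl)c32)c1` gives 1410 nM in this assay. Compound 2 stands second highest of the three numbers; its nearest neighbour is compound 1, and its furthest is compound 3, and both gaps lie within the scatter of repeated measurements, so no order among the three is established.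

Compound 4 `ClCc1ccccc1Cn1cnc2nc(Cl)nc(Cl)c21` has not yet been measured in this assay. It differs from compound 2 by chloro in place of hydrogen on an aromatic carbon, a chloro in place of hydrogen on an aromatic carbon. For the measured compounds named here, no measured pair shows this change in isolation. Compound 3, which carries the same dichloro core with the substituted benzyl attached at a different position, gives 1410 nM, but this is not a single-change comparison. The step from compound 2 to compound 4 is expected to be small, if anything toward a lower number, and is estimated as a 1.4-fold lower number from compound 2 to compound 4 (0.14 log units; within the scatter), not clearly beyond the scatter. Compound 4 is therefore estimated at 1600 nM, with a range from 700 nM to 3600 nM.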

Compound 4, concentration for 50% growth inhibition: 250 nM
The estimate for compound 4 lay 6.4-fold (0.81 log units) above the measured number; the measured number lies below the stated range.
By their numbers in this assay, from the lowest: compound 4; then compounds 3, 2 and 1 (each within the scatter of the next, the first and the last beyond it).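

In this assay, for the compounds shown here, chloro in place of hydrogen on the aromatic carbon between two ring nitrogen atoms is the first single change that can be read, and it gives an 8.9-fold lower number from compound 2 to compound 4 (0.95 log units; beyond the scatter); the three earlier compounds established no order, so they gave no sign that this position could move the number so far. The chloro does not set the number alone: compound 3 also carries chloro at this carbon and differs from compound 4 in one other place, yet compound 3 gives 1410 nM, so the effect at this position depends on the rest of the molecule, at least in this one comparison. Nothing in hand bears on why the number falls at this position.

Still open, from the compounds shown here alone, is whether another group on this carbon, such as an amine, a methoxy group or a fluoro, would keep the low number of compound 4 or whether it is particular to chloro. Also open, going by these compounds, is whether the same change would give a step of similar size on compound 1, which carries hydrogen at this carbon.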